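Amino for Chloro on a Shared Urea Core

The source may report more compounds than this note shows. Statements on the series, on what has been measured and on what is new or still open speak of the compounds shown alone.

Compounds measured so far:
compound 1, `Nc1nn(C(=O)Nc2ccc(Cc3ccccc3)cc2)c2ccccc12`, 84600 nM
compound 2, `Nc1nn(C(=O)Nc2ccc(Cc3ccccc3)cc2)c2ccc(Cl)cc12`, 60600 nM

Compound 1 and compound 2 share one core and differ in one place. In a functional assay on NCI-H460 cells (Homo sapiens) for antiproliferative activity, read by sulforhodamine B assay, with a stated time of 48 h (a lower number here means that less compound is tolerated, a higher number that more compound is tolerated), compound 1 gives 84600 nM and compound 2 gives 60600 nM. The step of a 1.4-fold lower number from compound 1 to compound 2 (0.14 log units; within the scatter) stays within the scatter, so the two compounds cannot be ordered. Among the compounds with values here, compound 2 has the lower of the two numbers, with compound 1 the only neighbour.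

Compound 3, `Nc1ccc2c(c1)c(N)nn2C(=O)Nc1ccc(Cc2ccccc2)cc1`, is not yet measured. It differs from compound 2 by amino in place of chloro on an aromatic carbon. Within the data shown here, the only measured step at this position, a 1.4-fold lower number from compound 1 to compound 2 (0.14 log units; within the scatter), moved the number by less than the scatter, which shows that at least one exchange on this ring left the read-out unchanged. Among the measured compounds shown here, no compound with an amino group at this place has been measured, so nothing shows how this particular group behaves.

Compound 3 is therefore expected to sit near compound 2, at about 75000 nM, with a range from 30000 nM to 180000 nM. The step this estimate means, a 1.2-fold higher number from compound 2 to compound 3 (0.09 log units; within the scatter), is expected to stay within the scatter.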

Compound 3, concentration lethal to 50% of the cells: > 100000 nM
Compound 3 was reported as a limit (the forecaster's own chance of this, stated with the estimate: 15%); middle value at least 1.3-fold (0.12 log units) away from the limit.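

The reading for compound 3 in this assay is a limit and not a number: the limit of > 100000 nM in this assay, at which 1 of the 3 values shown sits. Within the data shown here, this is the first exchange at this position to end in a limit, since hydrogen and chloro on this aromatic carbon both gave readable numbers, so amino is the only one of the three groups whose size of effect stays unfixed. Amino in place of chloro gives an at least 1.6-fold higher number from compound 2 to compound 3 (0.21 log units; that floor lies within the scatter), and amino in place of hydrogen gives an at least 1.1-fold higher number from compound 1 to compound 3 (0.07 log units; that floor lies within the scatter), so neither step separates the compounds, and the position is still not shown to matter for this read-out.

The compounds shown leave open how far compound 3 really lies past the limit, and so whether amino differs from chloro or hydrogen by more than the scatter. They also leave open whether another group on this aromatic carbon, such as a hydroxyl, a methoxy or a carboxylic acid, would give a readable number clearly apart from those of compound 1 and compound 2.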